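Working notes: halophenyl swap and cell toxicity in the series

The compounds below may be only part of what the source reports. "The series", "measured", "known", "first", "only" and "open" are said of these compounds alone.

Of the compounds shown here, three built on one shared core have been measured in an ADME assay on A549 cells (Homo sapiens) for cytotoxicity, read by CellTiter-Glo; on this read-out lower numbers stand for higher toxicity in this test and higher numbers for lower toxicity in this test. Compound 1 `Cc1c(Cc2ccc(C(F)(F)F)cc2)c(=O)oc2cc(OCC(O)CN3CCC(C(N)=O)CC3)ccc12` gives 89300 nM. Compound 2 `Cc1c(Cc2ccc(OC(F)(F)F)cc2)c(=O)oc2cc(OCC(O)CN3CCC(C(N)=O)CC3)ccc12` gives 68200 nM; the step of a 1.3-fold lower number from compound 1 to compound 2 (0.12 log units; within the scatter) is within the scatter. Compound 3 `Cc1c(Cc2ccc(-c3ccc(F)cc3)cc2)c(=O)oc2cc(OCC(O)CN3CCC(C(N)=O)CC3)ccc12` gives 19300 nM, the lowest of the three numbers; the steps of a 4.6-fold lower number from compound 1 to compound 3 (0.67 log units; beyond the scatter) and a 3.5-fold lower number from compound 2 to compound 3 (0.55 log units; beyond the scatter) are both beyond the scatter, so compound 3 stands apart from compound 1 and compound 2 in this assay.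

Compound 4 `Cc1c(Cc2ccc(-c3ccc(Cl)cc3)cc2)c(=O)oc2cc(OCC(O)CN3CCC(C(N)=O)CC3)ccc12` is not yet measured. Its change from compound 3 is chloro in place of fluoro on an aromatic carbon of a six-membered aromatic ring of carbon only, para to a large group; cut one bond further out, 4-fluorophenyl to 4-chlorophenyl. Among the measured compounds shown here, no measured step swaps one halogen for another, so none bears directly on this change. For the measured compounds named here, the only steps that end at compound 3, a 4.6-fold lower number from compound 1 to compound 3 (0.67 log units; beyond the scatter) and a 3.5-fold lower number from compound 2 to compound 3 (0.55 log units; beyond the scatter), each replace a whole group by the 4-fluorophenyl ring, a larger change than the one now in question. A step of at most modest size is therefore expected in this assay, direction uncertain, a lower number somewhat more likely than a higher one. The estimate for compound 4 is 15000 nM, in the range 6000 nM to 35000 nM. This corresponds to an expected step of a 1.3-fold lower number from compound 3 to compound 4 (0.11 log units; within the scatter).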

Compound 4, half-maximal cytotoxic concentration: 32900 nM
Compound 4: the middle estimate sits 2.2-fold (0.34 log units) below what was measured; measured number inside the range.
By their numbers in this assay, from the lowest: compounds 3 and 4 (each within the scatter of the next); then compounds 2 and 1 (each within the scatter of the next).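

In this assay, among the compounds shown here, this is the first halogen swap at this position, on an aromatic carbon para to a large group, and it gives a 1.7-fold higher number from compound 3 to compound 4 (0.23 log units; within the scatter), so 4-fluorophenyl and 4-chlorophenyl cannot be told apart here. For the compounds shown here, the separation from the earlier groups persists with the new halogen, with a 2.1-fold lower number from compound 2 to compound 4 (0.32 log units; beyond the scatter) and a 2.7-fold lower number from compound 1 to compound 4 (0.43 log units; beyond the scatter), so across these four compounds the lower numbers go with the two halophenyl groups, whichever of the two halogens is present, and no compound goes against this. The data at hand offer no measured explanation for either the near-equality of the two halogens or the separation from trifluoromethyl and trifluoromethoxy.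

Still open, going by these compounds, is whether the halogen matters at all, since only fluoro and chloro have been compared at this place, and a plain phenyl, 4-methoxyphenyl or 4-aminophenyl group would test whether the outer ring alone carries the separation. Equally open, on these data alone, is whether the same reading would hold with a carboxylic acid or an amine elsewhere on the shared core.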